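The compounds below may be only part of what the source reports. "The series", "measured", "known", "first", "only" and "open" are said of these compounds alone.

Compound 1 `CCCOC(=O)Nc1ccc([Se]C#N)cc1` gives 9300 nM in a functional assay on CCRF-CEM cells (Homo sapiens) for cytotoxicity, read by MTT assay, with a stated time of 72 h; on this read-out lower numbers stand for stronger inhibition of growth and higher numbers for weaker inhibition of growth. Among the compounds with values here, the only other number comes from compound 2 `O=C(Nc1ccc([Se][Se]c2ccc(NC(=O)OCc3ccccc3)cc2)cc1)OCc1ccccc1`, which in this assay gives 6400 nM; the two numbers lie within the scatter of each other, so no order between them is claimed. Compound 3 `CC(C)COC(=O)Nc1ccc([Se]C#N)cc1` differs from compound 1 by methyl in place of hydrogen on a saturated chain carbon bound to two saturated chain carbons. No step between measured compounds exists for a change of this kind, and nothing in the numbers shown points one way or the other. For compound 3 a step of a 1.1-fold lower number from compound 1 to compound 3 (0.04 log units; within the scatter) is expected, that is, none beyond the scatter. Compound 3 is estimated at 8500 nM, with a range from 3500 nM to 20000 nM.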

Compound 3, concentration for 50% growth inhibition: 9300 nM
Compound 3: the middle estimate sits 1.1-fold (0.04 log units) below what was measured; measured number inside the range.
By their numbers in this assay, from the lowest: compounds 2, 1 and 3 (each within the scatter of the next).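

In this assay, methyl in place of hydrogen on a saturated chain carbon bound to two saturated chain carbons gives no change at the digits printed from compound 1 to compound 3 (within the scatter), the first step read at this position. Going from propoxy to isobutoxy therefore leaves the growth-inhibition read-out where it was, so this one added methyl is tolerated here. No available evidence bears on this result. As far as these compounds go, a longer chain, or an amine or a carboxylic acid carried on the chain, remains open, and one step cannot show whether larger groups at this carbon would behave the same way.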